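Acetoxymethyl in place of cyano on the fused core

The source may report more compounds than this note shows. Statements on the series, on what has been measured and on what is new or still open speak of the compounds shown alone.

Compound 1 `Cc1nc2c(OCc3ccccc3)cccn2c1C(N)=O`: 2%
Compound 2 `Cc1nc2c(OCc3ccccc3)cccn2c1C#N`: 4%
Compound 3 `Cc1nc2c(OCc3ccccc3)cccn2c1Br`: 63%

In a functional assay on the whole organism (stomach) for inhibition, with Canis familiaris (Canis lupus familiaris) as the target, at a dose of 5 mg/kg by the intravenous route (a lower number here means a weaker effect, a higher number a stronger effect of the compound at the dose given), compound 2 gives 4%, the second highest of the three numbers; its nearest neighbour is compound 1 with 2%, and compound 3 with 63% lies farthest from it. The step of a number 2 percentage points higher from compound 1 to compound 2 (within the scatter) shows that exchanging carbamoyl for cyano left the read-out unchanged within the scatter. The step of a number 59 percentage points higher from compound 2 to compound 3 (beyond the scatter), like a number 61 percentage points higher from compound 1 to compound 3 (beyond the scatter), shows that bromo at the same aromatic carbon gave a large rise. Compound 4 `CC(=O)OCc1c(C)nc2c(OCc3ccccc3)cccn12` carries the change (acetoxymethyl in place of cyano on an aromatic carbon). Among the compounds with values here, no measured step replaces cyano with acetoxymethyl, so the two steps from compound 2 bound what has been seen at this position: one change there did nothing, one changed the number greatly. Acetoxymethyl is neither of these groups. The estimate for compound 4 in this assay is therefore 20%, with a range of 0% to 55%, which means an expected step of a number 16 percentage points higher from compound 2 to compound 4 (beyond the scatter) from compound 2 that is uncertain in size and could stay within the scatter.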

Compound 4, a percentage reported as inhibition, in the whole organism at one dose (the size of the read-out at that dose, not a potency): 87%
Compound 4: middle estimate off by 67 percentage points, on the low side; measured number outside the range, above it.
By their numbers in this assay, from the lowest: compounds 1 and 2 (each within the scatter of the next); then compound 3; then compound 4.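

In this assay, within the data shown here, acetoxymethyl takes this aromatic carbon of the five-membered ring beyond the highest number the earlier compounds had reached, with a number 24 percentage points higher from compound 3 to compound 4 (beyond the scatter), so bromo no longer marks the top of what the position allows. Set against the two groups at the low end, the change is far larger, with a number 83 percentage points higher from compound 2 to compound 4 (beyond the scatter) and a number 85 percentage points higher from compound 1 to compound 4 (beyond the scatter), which shows that a high number here is not confined to bromo and that a group joined to the ring through carbon does not by itself keep the number low, as cyano and carbamoyl had left possible. No measurement at hand accounts for why the read-out moves in this way.

Whether hydroxymethyl, aminomethyl or a plain ethyl group at this carbon would stay near compound 4 remains open, so the compounds shown do not tell which part of acetoxymethyl goes with the rise. All four readings also come from one dose, which leaves open how the compounds would compare across a range of doses.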